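The source may hold more compounds than are shown below. What is called first, only, known or untested is meant among the compounds shown, and "the series" means these compounds.

Series notes, ester side chain of the shared core.

Compound 1 `COCCOC(=O)C(O)Cn1cnc2c(N)ncnc21` gives in a functional assay on HeLa cells (Homo sapiens) for cytotoxicity (a lower number here means that less compound is tolerated, a higher number that more compound is tolerated), only a limit, > 400 ug/mL, not a number. Compound 2 `CCOC(=O)C(O)Cn1cnc2c(N)ncnc21` also gives only a limit in this assay, > 400 ug/mL. Compound 3 `CCCOC(=O)C(O)Cn1cnc2c(N)ncnc21` likewise reaches only a limit there, > 400 ug/mL. All three therefore sit at the same point, (the limit of > 400 ug/mL in this assay, at which 3 of the 3 values shown sit), and none of the three values is a number.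

The steps between them are accordingly not readable: a step that the two limits leave unreadable from compound 1 to compound 2, a step that the two limits leave unreadable from compound 1 to compound 3 and a step that the two limits leave unreadable from compound 2 to compound 3 show only that none of the three members was tolerated less than the limit allows.

Compound 4 `Nc1ncnc2c1ncn2CC(O)C(=O)OC1CCCCC1` is not yet measured in this assay. It differs from compound 1 by cyclohexyl in place of 2-methoxyethyl on an oxygen next to a carbonyl group. The measured steps that bear on this change are those that vary the same ester oxygen substituent, and all of them are unreadable, so no direction and no size beyond the scatter can be taken from them. What the three limits do show is that every ester tried here was tolerated up to the limit.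

Compound 4 is therefore expected to behave like the rest of the series, with a step of a number no higher from compound 1 to compound 4 (the limit leaves the size open) from compound 1, and an estimated value of 400 ug/mL in this assay, within a range of 150 ug/mL to 1000 ug/mL.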

Compound 4, minimum cytotoxic concentration: 100 ug/mL
Estimate against measurement, compound 4: 4.0-fold (0.60 log units) above, and the stated range ends above it.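

Cyclohexyl in place of 2-methoxyethyl on an oxygen next to a carbonyl group gives in this assay an at least 4.0-fold lower number from compound 1 to compound 4 (0.60 log units; beyond the scatter) and so shows that this position can shift the tolerated concentration, which the earlier steps could not show, as none of them can be read. The same holds from the two other esters, with cyclohexyl in place of propyl giving an at least 4.0-fold lower number from compound 3 to compound 4 (0.60 log units; beyond the scatter) and cyclohexyl in place of ethyl giving an at least 4.0-fold lower number from compound 2 to compound 4 (0.60 log units; beyond the scatter) so the step is not tied to the 2-methoxyethyl group alone. Among the four esters only compound 4 carries a ring and only compound 4 gives a number, while the three open-chain esters stay at one point: the limit of > 400 ug/mL in this assay, at which 3 of the 4 values shown sit.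

Whether the step belongs to the ring itself or to the larger carbon substituent stays open, since the open-chain esters shown stop at propyl and 2-methoxyethyl. A longer chain such as hexyl, a smaller ring such as cyclopentyl, or a carboxylic acid in place of the ester would each test a different part of this question.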